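The source may hold more compounds than are shown below. What is called first, only, known or untested is meant among the compounds shown, and "the series" means these compounds.

Measured compounds:
compound 1 `Cc1ccc(-n2nncc2CN2C(=O)C3(C(C#N)=C(N)Oc4c3c3nc5ccccc5nc3c3ccccc43)c3ccccc32)cc1C`
compound 2 `Cc1ccc(C)c(-n2nncc2CN2C(=O)C3(C(C#N)=C(N)Oc4c3c3nc5ccccc5nc3c3ccccc43)c3ccccc32)c1`
compound 3 `CCc1ccccc1-n1nncc1CN1C(=O)C2(C(C#N)=C(N)Oc3c(N)cc4nc5ccccc5nc4c32)c2ccccc21`

In a functional assay on A549 cells (Homo sapiens) for antiproliferative activity, read by MTT assay, with a stated time of 48 h (on this read-out higher numbers stand for weaker inhibition and lower numbers for stronger inhibition), compound 1 gives > 50000 nM, a limit of the assay and not a number. Compound 2 likewise gives only a limit, > 50000 nM. The step from compound 1 to compound 2, a step that the two limits leave unreadable from compound 1 to compound 2, is therefore unreadable in size. Within the data shown here, compound 3 gives 24600 nM, the only number in the set. The other two values sit at the limit of > 50000 nM in this assay, at which 2 of the 3 values shown sit.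

Compound 4 `N#CC1=C(N)Oc2c(N)cc3nc4ccccc4nc3c2C12C(=O)N(Cc1cnnn1-c1cccc(Br)c1)c1ccccc12` differs from compound 3 by 3-bromophenyl in place of 2-ethylphenyl on an aromatic nitrogen. Among the measured compounds shown here, no measured step of readable size bears on this change; the only step at the same aromatic nitrogen is the unreadable one from compound 1 to compound 2. No shift beyond the scatter is expected. Compound 4 is estimated at 25000 nM, within 8000 nM to 80000 nM. The expected step is a 1.0-fold higher number from compound 3 to compound 4 (0.01 log units; within the scatter), inside the scatter.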

Compound 4, half-maximal inhibitory concentration: 18900 nM
The estimate for compound 4 lay 1.3-fold (0.12 log units) above the measured number; the range from low to high includes it.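

In this assay, among these compounds, the first readable step at this aromatic nitrogen is a 1.3-fold lower number from compound 3 to compound 4 (0.11 log units; within the scatter). On this shared core, 3-bromophenyl and 2-ethylphenyl therefore cannot be told apart, and this pair gives no sign that the change matters for the read-out. The only earlier step at this nitrogen cannot be read, as both of its values are limits of the assay and not numbers: the limit of > 50000 nM in this assay, at which 2 of the 4 values shown sit.

From the compounds shown here alone, whether a phenyl ring carrying an amine or a carboxylic acid at this nitrogen would shift the read-out remains open.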